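Changing the aryl group on the double-bonded chain

The compounds below may be only part of what the source reports. "The series", "measured", "known", "first", "only" and "open" are said of these compounds alone.

In a functional assay on HCT-116 cells (Homo sapiens) for antiproliferative activity, with a stated time of 72 h (a higher number here means a weaker inhibitor, a lower number a stronger inhibitor), compound 1 `COc1ccccc1/C=C/c1nc(Nc2ccc(O)cc2)c2ccccc2n1` gives 17900 nM, and compound 2 `COc1ccccc1/C=C/c1nc(Nc2cccc(O)c2)c2ccccc2n1` gives 16400 nM. Among the compounds with values here, the only measured step is a 1.1-fold lower number from compound 1 to compound 2 (0.04 log units; within the scatter), so compound 1 stands level with compound 2 within the scatter. That step exchanges 4-hydroxyphenyl for 3-hydroxyphenyl on a nitrogen. Compound 3 `Oc1ccc(Nc2nc(/C=C/c3cccc(Cl)c3)nc3ccccc23)cc1` differs from compound 1 elsewhere: 3-chlorophenyl in place of 2-methoxyphenyl on a double-bonded chain carbon bound to a double-bonded chain carbon, with 3-chlorophenyl in place of 2-methoxyphenyl on a double-bonded chain carbon. Within the data shown here, no measured step covers this place, so nothing beyond the scatter is expected in this assay, and direction stays open. The expected step is a 1.3-fold lower number from compound 1 to compound 3 (0.11 log units; within the scatter). For compound 3 the estimate is 14000 nM, with an expected range of 5000 nM to 35000 nM.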

Compound 3, half-maximal inhibitory concentration: 22700 nM
For compound 3 the middle estimate is 1.6-fold (0.21 log units) below the measured one; the range from low to high includes it.
By their numbers in this assay, from the lowest: compounds 2, 1 and 3 (each within the scatter of the next).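

In this assay, 3-chlorophenyl in place of 2-methoxyphenyl on a double-bonded chain carbon gives a 1.3-fold higher number from compound 1 to compound 3 (0.10 log units; within the scatter). Within the data shown here, this is the first reading at this position, and this exchange of one substituted phenyl for another leaves the number within the scatter. No evidence on record bears on this result.

Going by these compounds, whether a phenyl carrying an amine or a carboxylic acid would move the number beyond the scatter remains open. The compounds shown also do not separate the identity of the substituent from its place on the phenyl.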